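From cyclopropyl to 3-cyanophenyl on the sulfonyl sulfur

The source may hold more compounds than are shown below. What is called first, only, known or untested is meant among the compounds shown, and "the series" means these compounds.

In an ADME assay (liver) for metabolic stability, with Liver microsome (Homo sapiens) as the target, read by LC-MS, using microsomes and NADPH, with a stated time of 5 min, at 37 degrees C (on this read-out lower numbers stand for slow clearance and higher numbers for fast clearance), compound 3 (`CCn1c([C@@H](C)NS(=O)(=O)C2CC2)nc2ccc(C(F)(F)F)cc21`) gives < 3 mL.min-1.g-1 as a limit and not a number, and it stands at the slow-clearance end of the three compounds measured. Compound 4 (`CCn1c([C@@H](C)NS(=O)(=O)c2cccc(C#N)c2)nc2ccc(C(F)(F)F)cc21`) carries 3-cyanophenyl in place of cyclopropyl on a sulfonyl sulfur. Among the compounds with values here, no measured step isolates this change. The expectation therefore rests on two compounds with a phenyl ring on the sulfonyl sulfur, though on other cores: compound 1 (`CCn1c(C(C)NS(=O)(=O)c2ccc(Cl)cc2)nc2ccncc21`) at 93 mL.min-1.g-1 and compound 2 (`CCn1c(C(C)NS(=O)(=O)c2ccc(Cl)cc2)nc2ncccc21`) at 15 mL.min-1.g-1 in this assay. A rise in clearance is expected, with an estimated step (an at least 3.3-fold higher number from compound 3 to compound 4 (0.52 log units; beyond the scatter)) that likely exceeds the scatter. In this assay compound 4 is expected at 10 mL.min-1.g-1 (estimated range 3 mL.min-1.g-1 to 40 mL.min-1.g-1).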

Compound 4, intrinsic clearance in microsomes: > 100 mL.min-1.g-1
Compound 4 was reported as a limit; the forecaster's own chance of this, stated with the estimate: 25%; at least 10-fold (1.00 log units) between middle value and limit.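

In this assay, the sulfonyl sulfur of this core proves a position where the group carried matters greatly: 3-cyanophenyl in place of cyclopropyl gives an at least 33-fold higher number from compound 3 to compound 4 (1.52 log units; beyond the scatter). Within the data shown here, compound 1 and compound 2 carry a phenyl ring on other cores, so only this pair shows the change on one core. Compound 4 stands at a limit of the assay and not at a number: the limit of > 100 mL.min-1.g-1 in this assay, at which 1 of the 4 values shown sits.

As far as these compounds go, whether the rise belongs to the phenyl ring or to its nitrile remains open. Where an ethyl chain or an amine on the sulfonyl sulfur would fall in this assay is also open.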